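This account rests on a few compounds, and the source may have more. Where it says the series, first, only, none or still open, it means among the compounds named here.

Measured compounds:
compound 1 `CN1C(=O)CN(C2CCCC2)c2nc(Nc3ccc(N4CCCCC4)cn3)ncc21` — > 30000 nM in a functional assay on HeLa cells (Homo sapiens) for inhibition, read by MTT assay, with a stated time of 48 h; on this read-out higher numbers stand for weaker inhibition and lower numbers for stronger inhibition
compound 2 `CCN1C(=O)CN(C2CCCC2)c2nc(Nc3ccc(N4CCN(C)CC4)cn3)ncc21` — 29100 nM

Going by the values given here, compound 2 is the only compound with a number; in this assay compound 2 gives 29100 nM. The other value is a limit of the assay: compound 1 gives > 30000 nM, a limit and not a number, which is the limit of > 30000 nM in this assay, at which 1 of the 2 values shown sits. Compound 3 `CCN1C(=O)CN(C2CCCC2)c2nc(Nc3ccc(N4CCCCC4)cn3)ncc21` has not been measured. It differs from compound 2 in one place: piperidin-1-yl in place of 4-methylpiperazin-1-yl on an aromatic carbon. Compound 1 also carries the piperidin-1-yl group and sits at the limit. Among the compounds with values here, no measured step is available for this change, so the expectation for the step from compound 2 to compound 3 in this assay is a 1.0-fold higher number from compound 2 to compound 3 (0.01 log units; within the scatter), with no direction beyond the scatter. Compound 3 is therefore estimated at 30000 nM, between 10000 nM and 100000 nM.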

Compound 3, half-maximal inhibitory concentration: 17600 nM
Compound 3: middle estimate off by 1.7-fold (0.23 log units), on the high side, within the range that was stated.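

In this assay, placing piperidin-1-yl instead of 4-methylpiperazin-1-yl on the aromatic carbon gives a 1.7-fold lower number from compound 2 to compound 3 (0.22 log units; within the scatter), so going from a ring with 2 hetero atoms to a ring with 1 hetero atom makes no difference here that can be told from the scatter. Adding a methyl to the chain carbon bound to the amide-type nitrogen gives an at least 1.7-fold lower number from compound 1 to compound 3 (0.23 log units; that floor lies within the scatter). The value of compound 1 is a limit and not a number, so this step has only a floor: the limit of > 30000 nM in this assay, at which 1 of the 3 values shown sits.

The compounds shown leave open whether a different group on the same aromatic carbon, such as morpholin-4-yl or an open-chain dimethylamino group, would move the number beyond the scatter. They also leave open what a longer chain on the amide-type nitrogen, such as propyl or butyl, would do.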